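Mirror-image methyl on the piperazine of compound 3

This account rests on a few compounds, and the source may have more. Where it says the series, first, only, none or still open, it means among the compounds named here.

The series shares one core and varies the saturated ring that hangs from it. Compound 1 `COc1cc2c(cc1N1C[C@@H](C)N[C@@H](C)C1)N(S(=O)(=O)c1ccc(-c3ccccn3)cc1)CC2` gives 0.2 nM in a functional assay for agonist activity at growth hormone secretagogue receptor type 1 (Homo sapiens), read by FLIPR (a higher number here means that more compound is needed for the effect, a lower number that less compound is needed), and compound 2 `COc1cc2c(cc1N1C[C@@H](C)N[C@@H](C)C1)N(S(=O)(=O)c1ccc(-c3ccccn3)s1)CC2` gives 0.159 nM. Compound 3 `COc1cc2c(cc1N1CCN[C@@H](C)C1)N(S(=O)(=O)c1ccc(-c3ccccn3)s1)CC2` gives 3.16 nM, the highest number of the three; its nearest neighbour is compound 1, and its furthest is compound 2. Going by the values given here, the only single-point step recorded here is a 20-fold higher number from compound 2 to compound 3 (1.30 log units; beyond the scatter), a large one. Compound 4 `COc1cc2c(cc1N1CCN[C@H](C)C1)N(S(=O)(=O)c1ccc(-c3ccccn3)s1)CC2` is next: the two compounds have the same atoms and bonds and differ only in configuration as drawn: 1 of 1 stereo elements differ; a stereocentre at a saturated ring carbon is drawn S in compound 3 and R in compound 4. Among the compounds with values here, no measured pair in this set differs only in configuration, so the recorded step, which concerns a methyl group present or absent, says nothing direct about turning that methyl to the other face. The size of that step does show how sensitive this assay is to the methyl at this carbon, so a change beyond the scatter in either direction is possible. Compound 4 is therefore expected to give 5 nM, within 1 nM to 25 nM, an estimated step of a 1.6-fold higher number from compound 3 to compound 4 (0.20 log units; within the scatter).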

Compound 4, half-maximal effective concentration: 3.98 nM
Compound 4: the middle estimate sits 1.3-fold (0.10 log units) above what was measured; low and high end bracket the measured number.
By their numbers in this assay, from the lowest: compounds 2 and 1 (each within the scatter of the next); then compounds 3 and 4 (each within the scatter of the next).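

In this assay, turning the methyl to the other face gives a 1.3-fold higher number from compound 3 to compound 4 (0.10 log units; within the scatter), so at this saturated ring carbon the drawn configuration makes no difference that can be told from the scatter, and the comparison is a direct one: the fact that compounds 3 and 4 differ only in the configuration as drawn.

What compound 3 alone could not show is that the large step from the doubly methylated compound 2 does not depend on how the remaining methyl is drawn: a 25-fold higher number from compound 2 to compound 4 (1.40 log units; beyond the scatter) stands beside a 20-fold higher number from compound 2 to compound 3 (1.30 log units; beyond the scatter), and both are large.

The compounds shown leave open whether an ethyl or a hydroxymethyl group in place of this methyl would keep the number in the same range. They also leave open whether configuration would count at this carbon with both methyl groups present.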